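Methyl in place of methylsulfonyl: compound 3 to compound 4

A few compounds are considered here, and "the series" means these few. Any claim that something is new, unique, unknown or untested is made for them only; others in the source may bear on it.

Three members of the series have been measured in a functional assay on H22 cells (Mus musculus) for inhibition, read by MTT assay, with a stated time of 24 h; a lower number here means a stronger inhibitor, a higher number a weaker inhibitor. Compound 1 `FC(F)(F)c1cc(NC[C@H]2CCCN2)c2cn[nH]c2c1` gives 19700 nM. For compound 2 `O=[N+]([O-])c1ccc(CNc2cc(Br)cc3[nH]ncc23)cc1` the read-out is only a limit of the assay, > 20000 nM. Compound 3 `CS(=O)(=O)c1ccc(CNc2cc(C(F)(F)F)cc3[nH]ncc23)c([N+](=O)O)c1` likewise returns only a limit of the assay, > 20000 nM. Within the data shown here, compound 3 therefore stands at the weak end of what the numbers show: its value is a limit rather than a number, and compound 1 is the only member with a measured concentration. What the set shows as a whole is the limit of > 20000 nM in this assay, at which 2 of the 3 values shown sit.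

Compound 4 `Cc1ccc(CNc2cc(C(F)(F)F)cc3[nH]ncc23)c([N+](=O)O)c1` is the next member. It differs from compound 3 in one place: methyl in place of methylsulfonyl on an aromatic carbon.

Among the measured compounds shown here, no measured pair differs in a single place, so no measured step is available to set the expected size of this change. Since compound 3 gives only a limit, the estimated step of a number no higher from compound 3 to compound 4 (the limit leaves the size open) is expected to stay within the scatter of this assay, with no clear direction. Compound 4 is expected to give 20000 nM in this assay, within a range from 7000 nM to 60000 nM, and a limit rather than a number is about as likely as a measured value.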

Compound 4, half-maximal inhibitory concentration: 1340 nM
Estimate against measurement, compound 4: 15-fold (1.17 log units) above; measured number outside the range, below it.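

In this assay, the series now has its first step between compounds that differ in one place: an at least 14-fold lower number from compound 3 to compound 4 (1.17 log units; beyond the scatter). Among these compounds, this shows that the group on this aromatic carbon, meta to a group of 3 heavy atoms and para to a large group, can shift the read-out well beyond the scatter, which the earlier compounds could not show. The value of compound 3, > 20000 nM, is a limit of the assay and not a number, so the step has no fixed size, and the limit still marks much of the set: the limit of > 20000 nM in this assay, at which 2 of the 4 values shown sit.

This single step cannot separate the departure of the 2 hydrogen-bond acceptors of methylsulfonyl from the change from 4 heavy atoms to 1, so it assigns no cause to either. From the compounds shown here alone, whether an amine, a carboxylic acid or a longer chain on this carbon would read like methyl or like methylsulfonyl remains open, as does whether the lower number follows from methyl itself or only from the absence of methylsulfonyl.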